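Trifluorophenyl for fluorophenyl: a cytotoxicity step on Vero cells

The source may hold more compounds than are shown below. What is called first, only, known or untested is meant among the compounds shown, and "the series" means these compounds.

Compound 1, `C[C@]1(CN2CCn3nc(-c4ccc(F)c(F)c4)nc3C2)Cn2cc([N+](=O)[O-])nc2O1`: "not determined" (no result reported) in this assay.
Compound 2, `C[C@]1(CN2CCc3nc(-c4cccc(F)c4)ccc3C2)Cn2cc([N+](=O)[O-])nc2O1`: > 32 ug/mL in this assay, a limit of the assay and not a number.

The account follows one step. In an ADME assay on Vero cells (Chlorocebus sabaeus) for cytotoxicity, read by MTT assay, with a stated time of 72 h (on this read-out lower numbers stand for higher toxicity in this test and higher numbers for lower toxicity in this test), compound 2 gives > 32 ug/mL, which is a limit rather than a measured number. Among the measured compounds shown here, compound 1 has no reported result in this assay, so compound 2 stands alone as the only entry with any reading, and that reading sits at the limit of > 32 ug/mL in this assay, at which 1 of the 2 values shown sits.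

Compound 3, `C[C@]1(CN2CCc3nc(-c4cc(F)c(F)c(F)c4)ccc3C2)Cn2cc([N+](=O)[O-])nc2O1`, is not yet measured. It differs from compound 2 by 3,4,5-trifluorophenyl in place of 3-fluorophenyl on an aromatic carbon.

For the measured compounds named here, no step between measured compounds is available, so the size of this change in this assay cannot be read from any pair. The expectation rests only on the limit of compound 2: the step from compound 2 to compound 3 is expected to be none beyond the scatter, a step that the limit leaves unreadable from compound 2 to compound 3, with compound 3 most likely also reported as a limit. Compound 3 is therefore estimated at 40 ug/mL, expected to fall between 16 ug/mL and 100 ug/mL.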

Compound 3, half-maximal cytotoxic concentration: > 32 ug/mL
Compound 3: only a limit was reported; the forecaster's own chance of this, stated with the estimate: 75%; the middle value lies beyond the limit too.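

No new step can be read from compound 2 to compound 3: in this assay, each of the two compounds carries only a limit of the assay and not a number. The compounds shown leave open what single value either would give, and whether 3,4,5-trifluorophenyl in place of 3-fluorophenyl changes cytotoxicity at all.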